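A few compounds are considered here, and "the series" means these few. Any claim that something is new, unique, unknown or untested is made for them only; others in the source may bear on it.

Working notes on a short series sharing one core, read in a functional assay on BT-549 cells (Homo sapiens) for antiproliferative activity, read by MTT assay, with a stated time of 48 h; a lower number here means a stronger inhibitor, a higher number a weaker inhibitor. Compound 1 (`CCN1C(=O)C(O)(Cc2nnn[nH]2)c2ccccc21`) gives > 100000 nM, which is a limit and not a number. Compound 2 (`CN1C(=O)C(O)(Cc2nnn[nH]2)c2cc(Cl)ccc21`) gives > 100000 nM, which is also a limit and not a number. Going by the values given here, the series so far therefore stands at the limit of > 100000 nM in this assay, at which 2 of the 2 values shown sit, and compound 2 offers no exact value as a starting point.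

Compound 3 (`CCN1C(=O)C(O)(Cc2nnn[nH]2)c2cc(Cl)ccc21`) differs from compound 2 by one change: methyl in place of hydrogen on a saturated chain carbon bound to an amide-type nitrogen in a ring. This is methyl in place of hydrogen on a saturated chain carbon bound to an amide-type nitrogen in a ring, and it can also be read as methyl to ethyl. Among the compounds with values here, no measured step shows what this change does, so no direction is favoured and no shift beyond the scatter is expected in this assay. The expected outcome is a number no higher from compound 2 to compound 3 (the limit leaves the size open), and a further report as a limit is the most likely reading. For compound 3 the estimated value is 100000 nM, with an expected range of 50000 nM to 200000 nM.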

Compound 3, half-maximal inhibitory concentration: 85400 nM
Beside the measured number, compound 3's estimate is 1.2-fold (0.07 log units) above it; the range from low to high includes it.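

In this assay, going by these compounds alone, compound 3 gives 85400 nM, the first exact number, so the change from methyl to ethyl on a saturated chain carbon bound to an amide-type nitrogen in a ring can now be read against a real value, if only from one side. That change gives an at least 1.1-fold lower number from compound 2 to compound 3 (0.06 log units; that floor lies within the scatter), and chloro in place of hydrogen on an aromatic carbon gives an at least 1.1-fold lower number from compound 1 to compound 3 (0.06 log units; that floor lies within the scatter); both floors lie within the scatter, so neither change is yet shown to move the number by more than the scatter. Of the compounds shown, only compound 3 carries both the ethyl and the chloro, and only compound 3 reads as a number, while the rest of the series stays at the limit: the limit of > 100000 nM in this assay, at which 2 of the 3 values shown sit.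

The compounds shown leave open whether a longer chain in place of the ethyl, or an amine or a methoxy group in place of the chloro, would move the number beyond the scatter. Going by these compounds, the readings of compound 1 and compound 2 are limits, so the true size of both steps also stays open.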